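The compounds below may be only part of what the source reports. "The series", "measured", "known", "first", "only" and "open" are said of these compounds alone.

Compound 1 `ClCc1ccccc1Cn1cnc2ncnc(Cl)c21`: 18600 nM
Compound 2 `ClCc1cccc(Cn2cnc3nc(Cl)nc(Cl)c32)c1`: 400 nM

In a functional assay on SK-MEL-28 cells (Homo sapiens) for cytotoxicity, read by sulforhodamine B assay, with a stated time of 48 h (a higher number here means a weaker inhibitor of growth, a lower number a stronger inhibitor of growth), compound 1 gives 18600 nM, the higher of the two numbers. Compound 2 gives 400 nM, a gap well beyond the scatter, although the two compounds differ in more than one place. Compound 3 `ClCc1ccccc1Cn1cnc2nc(Cl)nc(Cl)c21` carries the change (chloro in place of hydrogen on an aromatic carbon), between two ring nitrogen atoms of the shared core. Going by the values given here, no measured pair shows this single change. Because compound 2 gives 400 nM while also bearing a second chloro group on its core, compound 3 is expected to reach a lower number, by a 9.3-fold lower number from compound 1 to compound 3 (0.97 log units; beyond the scatter). The estimate for compound 3 is 2000 nM, within 400 nM to 10000 nM.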

Compound 3, concentration for total growth inhibition: > 100000 nM
Compound 3 was reported as a limit; the forecaster's own chance of this, stated with the estimate: 5%; at least 50-fold (1.69 log units) between middle value and limit.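

In this assay, chloro in place of hydrogen on the aromatic carbon between two ring nitrogen atoms gives an at least 5.3-fold higher number from compound 1 to compound 3 (0.73 log units; beyond the scatter), so this single change weakens growth inhibition. Compound 1 and compound 2 differ in more than one place and could not isolate this position. The full size of the step stays unknown, since compound 3 is reported only as a limit: the limit of > 100000 nM in this assay, at which 1 of the 3 values shown sits.

As far as these compounds go, whether an amine or a methoxy group at this position would keep the growth inhibition of compound 1 remains open. So does whether the chloro change acts the same way when the rest of the molecule differs.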